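The source may report more compounds than this note shows. Statements on the series, on what has been measured and on what is new or still open speak of the compounds shown alone.

Values in a functional assay on HCT-116 cells (Homo sapiens) for antiproliferative activity, read by MTT assay, with a stated time of 72 h (a higher number here means a weaker inhibitor, a lower number a stronger inhibitor), for the series so far

- compound 1 `COc1ccc(/C=C2/CN(C)/C(=N/c3ccc(C)cc3)S2)cc1` gives 11100 nM
- compound 2 `COc1ccc(/C=C2/CN(C)/C(=N/c3ccc(Br)cc3)S2)cc1` gives 8900 nM

Compound 2 stands level with compound 1 on these numbers, since the two values lie within the scatter of each other and neither can be ranked over the other. Compound 3 `COc1ccc(/C=C2/CN(C)/C(=N/c3ccc(F)cc3)S2)cc1` is still to be measured. The change from compound 2 to compound 3 (fluoro in place of bromo on an aromatic carbon) is fluoro in place of bromo on an aromatic carbon, para to a large group.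

Among the measured compounds shown here, one measured step bears on this change: bromo in place of methyl on an aromatic carbon (a 1.2-fold lower number from compound 1 to compound 2 (0.10 log units; within the scatter)). That step stays within the scatter. For the measured compounds named here, no fluoro compound has a value yet, so the reasoning rests on this single step and remains thin. On that basis, no step beyond the scatter is expected in this assay for the new swap. The estimated step (a 1.1-fold higher number from compound 2 to compound 3 (0.05 log units; within the scatter)) carries no meaningful direction. For compound 3 the estimated value is 10000 nM with an expected range from 5000 nM to 20000 nM in this measurement.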

Compound 3, half-maximal inhibitory concentration: 10000 nM
Beside the measured number, compound 3's estimate shows no gap at the digits printed; measured number inside the range.
By their numbers in this assay, from the lowest: compounds 2, 3 and 1 (each within the scatter of the next).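

In this assay, the swap to the 4-fluorophenyl group gives a 1.1-fold higher number from compound 2 to compound 3 (0.05 log units; within the scatter) and, measured against the methyl group, a 1.1-fold lower number from compound 1 to compound 3 (0.05 log units; within the scatter). With these two steps, methyl, bromo and fluoro on this aromatic carbon, para to a large group, all lie within the scatter of one another, so the earlier single step between methyl and bromo now extends to a third group and a direct exchange of one halogen for another, and the three compounds cannot be ranked. No supporting measurement bears on why these three groups give values so close together.

On these data alone, whether a markedly different group at this place, such as an amine, a carboxylic acid or a longer alkyl chain, would give a step beyond the scatter remains open. Also open, as far as these compounds go, is whether changes elsewhere on the shared core, such as replacing the methoxy group, would move the number more than the swaps at this aromatic carbon have done.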